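The source may hold more compounds than are shown below. What is called first, only, known or untested is meant among the compounds shown, and "the series" means these compounds.

Compound 1 `COc1ccc(N2CCN(Cc3csc(N)c3C(=O)c3ccc(Cl)cc3)CC2)cc1`: 0%
Compound 2 `Nc1scc(CN2CCN(c3cccnc3)CC2)c1C(=O)c1ccc(Cl)cc1`: 0%

In an assay on CHO cells for displacement of a labelled ligand from adenosine receptor A3 (Homo sapiens), read by scintillation counting, with a stated time of 120 min, tested at 10 uM (on this read-out higher numbers stand for more inhibition at the one concentration tested (going by the name of the read-out) and lower numbers for less inhibition), compound 2 gives 0%, level with compound 1 at the digits shown, the only measured step being no change at the digits printed from compound 1 to compound 2 (within the scatter). Compound 3 `Nc1scc(CN2CCN(c3ccc(F)c(F)c3)CC2)c1C(=O)c1ccc(Cl)cc1` differs from compound 2 by 3,4-difluorophenyl in place of pyridin-3-yl on an amine nitrogen in a ring, the same position that was varied before. Among the measured compounds shown here, only that earlier step bears on it, and it showed nothing beyond the scatter, so the change to compound 3 is expected to bring no step beyond the scatter either, no change at the digits printed from compound 2 to compound 3 (within the scatter). Compound 3 is therefore estimated at 0% in this assay, within -10% to 15%.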

Compound 3, a percentage reported as inhibition, at one concentration (the size of the read-out at that concentration, not a potency): 1%
Estimate against measurement, compound 3: 1 percentage points below; the range from low to high includes it.
By their numbers in this assay, from the lowest: compounds 1, 2 and 3 (each within the scatter of the next).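

In this assay, placing 3,4-difluorophenyl on this amine nitrogen gives a number 1 percentage points higher from compound 2 to compound 3 (within the scatter) and a number 1 percentage points higher from compound 1 to compound 3 (within the scatter). Three aromatic groups, one with a ring nitrogen and two with rings of carbon only, therefore read alike at this position, so swapping one for another has not separated these compounds. Nothing available explains these readings. Still open, going by these compounds, is whether a group of a different kind on this nitrogen, such as a benzyl group or a carboxylic acid on a longer chain, would read differently. Also open, on these data alone, is whether changes elsewhere on the shared core would do so.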